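The source may hold more compounds than are shown below. What is called first, only, known or untested is meant among the compounds shown, and "the series" means these compounds.

In an ADME assay on S9 fraction from liver (Mus musculus) for metabolic stability (a higher number here means that the compound lasts longer, a lower number that the compound disappears faster), compound 1 (`CC1(COCc2ccc(OCc3ccccc3)cc2)Cn2cc([N+](=O)[O-])nc2S1`) gives 0.517 h and compound 2 (`O=[N+]([O-])c1cn2c(n1)[S+]([O-])CC(OCc1ccc(OCc3ccccc3)cc1)C2`) gives 2.88 h as the higher of the two numbers, with a gap beyond the usual scatter. Compound 3 (`O=[N+]([O-])c1cn2c(n1)[S+]([O-])CC(OCc1ccc(OC(F)(F)F)cc1)C2`) differs from compound 2 by trifluoromethyl in place of benzyl on an oxygen on an aromatic ring in one place: trifluoromethyl in place of benzyl on an oxygen on an aromatic ring. Among the measured compounds shown here, no measured pair shows this exchange, so only a modest rise in this assay is expected. The estimated change is a 1.7-fold higher number from compound 2 to compound 3 (0.24 log units; within the scatter) and stays within the scatter. For compound 3 the estimated half-life is 5 h with 1.8 h to 14 h as the expected span.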

Compound 3, half-life in the Mus musculus assay: > 5.83 h
Compound 3: a limit, no number (the forecaster's own chance of this, stated with the estimate: 15%); middle value at least 1.1-fold (0.06 log units) away from the limit.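

In the Mus musculus assay compound 3 gives > 5.83 h, which is a limit of the assay and not a number. Read as a floor, the Mus musculus assay shows an at least 2.0-fold higher number from compound 2 to compound 3 (0.30 log units; that floor lies within the scatter), so the exchange of benzyl for trifluoromethyl on this oxygen costs no stability there, though the true size of the step stays unknown. In a physicochemical assay for solubility, read by HPLC, measured as kinetic solubility (on this read-out lower numbers stand for lower solubility and higher numbers for higher solubility), compound 2 gives 5.4 ug/mL and compound 3 gives 39 ug/mL. The same exchange also raises the number in the physicochemical assay: the measured solubility of compound 2, 5.4 ug/mL, and of compound 3, 39 ug/mL, a 7.2-fold higher number (0.86 log units; beyond the scatter)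

Going by these compounds, what remains open is how long compound 3 actually lasts. Also open, on these data alone, is whether a methyl or a difluoromethyl group on this oxygen would behave like trifluoromethyl.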